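Phenyl Swapped for Methyl on the Ring Nitrogen

This account rests on a few compounds, and the source may have more. Where it says the series, first, only, none or still open, it means among the compounds named here.

Compound 1 `Cc1ccccc1NC(=O)Nc1cc(C(C)(C)C)nn1-c1ccccc1`: 1.2 degrees C
Compound 2 `CC(C)(C)c1cc(NC(=O)Nc2cc(C(F)(F)F)cc(C(F)(F)F)c2)n(-c2ccccc2)n1`: 0.8 degrees C
Compound 3 `Cc1ccc(F)cc1NC(=O)Nc1cc(C(C)(C)C)nn1-c1ccccc1`: 1.6 degrees C

All three were tested in an assay on isolated protein for inhibition of Ephrin type-A receptor 2 (Homo sapiens), read by thermal shift assay, tested at 10 uM; on this read-out lower numbers stand for weaker stabilisation of the target and higher numbers for stronger stabilisation of the target against heat. Compound 2 gives the lowest of the three numbers, yet its distances to compound 1 and to compound 3 both lie within the scatter, so no order among them can be claimed. Among the measured compounds shown here, the only single-point step among them, a number 0.40 degrees C higher from compound 1 to compound 3 (within the scatter), is also within the scatter. Compound 4 `Cn1nc(C(C)(C)C)cc1NC(=O)Nc1cc(C(F)(F)F)cc(C(F)(F)F)c1` differs from compound 2 by methyl in place of phenyl on an aromatic nitrogen. For the measured compounds named here, no measured step touches that position, and the one step known says nothing about it, so there is no ground to expect a move beyond the scatter. The step of no change at the digits printed from compound 2 to compound 4 (within the scatter) is expected to stay within the scatter. The estimate for compound 4 is 0.8 degrees C, with a range from -0.4 degrees C to 2 degrees C.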

Compound 4, shift of the target's melting temperature: 0.4 degrees C
Beside the measured number, compound 4's estimate is 0.40 degrees C above it; the range from low to high includes it.
By their numbers in this assay, from the lowest: compounds 4, 2, 1 and 3 (each within the scatter of the next, the first and the last beyond it).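

In this assay, among the compounds shown here, the step of a number 0.40 degrees C lower from compound 2 to compound 4 (within the scatter) is the first reading at this position, and it lies within the scatter. Phenyl, with 6 heavy atoms, can thus give way to methyl, with 1 heavy atom, on this aromatic nitrogen without a readable change in this pair. No supporting data bear on this result. From the compounds shown here alone, whether a longer chain or a carboxylic acid on that nitrogen would move the number beyond the scatter stays open. So does whether the same swap would leave compound 1 or compound 3 equally unmoved.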